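The compounds below may be only part of what the source reports. "The series", "measured", "known", "first", "only" and "open" are said of these compounds alone.

Working notes on the amide series. Two compounds have numbers in a functional assay on the whole organism (integument) for inhibition, with Chilo suppressalis as the target, read by scintillation counting, with a stated time of 72 h (a lower number here means a stronger inhibitor, a higher number a weaker inhibitor), so far. Compound 1 `COc1ccccc1C(=O)Nc1nnc(-c2ccc(Cl)cc2)s1` gives 53.7 nM in this assay. Going by the values given here, compound 2 `COc1cccc(OC)c1C(=O)Nc1nnc(-c2ccc(C(C)(C)C)cc2)s1` gives 912 nM in this assay, the highest of the two numbers; compound 1 sits at a lower number by a gap that is beyond the scatter, but the two differ in more than one place, so no single step is read from that pair.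

Compound 3 `COc1cccc(OC)c1C(=O)Nc1nnc(-c2ccc(C#N)cc2)s1` is not yet measured. It differs from compound 2 by cyano in place of tert-butyl on an aromatic carbon. Among the compounds with values here, no measured pair shows this change, so the size of the step in this assay is not known from the data. The expectation is a moderate move to a lower number, from compound 2 to compound 3, of a 2.3-fold lower number from compound 2 to compound 3 (0.36 log units; beyond the scatter), with wide uncertainty. The estimate for compound 3 in this assay is 400 nM, in the range 100 nM to 1500 nM.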

Compound 3, half-maximal inhibitory concentration: 209 nM
Estimate against measurement, compound 3: 1.9-fold (0.28 log units) above; the range from low to high includes it.
By their numbers in this assay, from the lowest: compound 1; then compound 3; then compound 2.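

Going by these compounds alone, compound 2 and compound 3 give the first single-place step: in this assay, cyano in place of tert-butyl on an aromatic carbon, para to a large group, gives a 4.4-fold lower number from compound 2 to compound 3 (0.64 log units; beyond the scatter). The position therefore does not depend on tert-butyl, and the number falls as 4 heavy atoms leave and 2 enter, with 1 hydrogen-bond acceptor gained. This one pair cannot separate the loss of heavy atoms from the gain of the acceptor, and no measurement shown explains the step.

Steps involving compound 1 cannot be read, as it differs from compound 2 and compound 3 in more than one place, so it remains open whether chloro or cyano is preferred on a shared background. Also open, from the compounds shown here alone, is how an amine or a carboxylic acid would behave on this aromatic carbon.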